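The source may report more compounds than this note shows. Statements on the series, on what has been measured and on what is new or still open speak of the compounds shown alone.

Among the measured compounds shown here, compound 1 `COc1cc(-c2cc(/C=C/C(=O)c3ccc(N)cc3)[nH]n2)cc(OC)c1OC` gives 9980 nM in a functional assay on SNB-19 cells (Homo sapiens) for inhibition, read by sulforhodamine B assay, with a stated time of 48 h (a lower number here means a stronger inhibitor of growth, a higher number a weaker inhibitor of growth), the second highest of the three numbers so far. Its nearest neighbour, compound 3 `COc1ccc(-c2cc(/C=C/C(=O)c3ccc(N)cc3)[nH]n2)cc1OC`, gives 18000 nM, and compound 2 `COc1ccc(-c2cc(/C=C/C(=O)c3ccc(OC)c(OC)c3)[nH]n2)cc1` gives 5280 nM; both lie within the scatter of compound 1. For the measured compounds named here, the one single-point step measured, a 1.8-fold higher number from compound 1 to compound 3 (0.26 log units; within the scatter), concerns a different change from the one now at hand. Compound 4 `COc1ccc(C(=O)/C=C/c2cc(-c3cc(OC)c(OC)c(OC)c3)n[nH]2)cc1OC` differs from compound 1 by 3,4-dimethoxyphenyl in place of 4-aminophenyl on a carbonyl carbon. Going by the values given here, no measured step bears on this exchange directly; compound 2 carries the entering group but differs from compound 1 in a second place too, and the two values show no separation beyond the scatter. Compound 4 is therefore expected near 5000 nM, between 1500 nM and 15000 nM, a step of a 2.0-fold lower number from compound 1 to compound 4 (0.30 log units; within the scatter) that is estimated to stay within the scatter.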

Compound 4, concentration for total growth inhibition: 3010 nM
For compound 4 the middle estimate is 1.7-fold (0.22 log units) above the measured one, within the range that was stated.
By their numbers in this assay, from the lowest: compounds 4, 2, 1 and 3 (each within the scatter of the next, the first and the last beyond it).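

Among the compounds shown here, on this carbonyl carbon, 3,4-dimethoxyphenyl in place of 4-aminophenyl gives a 3.3-fold lower number from compound 1 to compound 4 (0.52 log units; beyond the scatter) in this assay, the first step between compounds differing in one place that lies beyond the scatter. For the compounds shown here, the only earlier such step concerned a different change and stayed within the scatter, so this is the first sign, still a modest one, that the number responds to the group at this position. Nothing measured here says why the number moves. From the compounds shown here alone, whether the departure of 4-aminophenyl or the arrival of 3,4-dimethoxyphenyl carries the step remains open, as does where 4-methoxyphenyl or 4-hydroxyphenyl on this carbonyl carbon would fall.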